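The source may report more compounds than this note shows. Statements on the series, on what has been measured and on what is new or still open speak of the compounds shown alone.

Compound 1 `OCc1cn(Cc2cccc(F)c2)c2ccccc12`: 40 nM; compound 2 `OCc1cn(Cc2ccccc2Cl)c2ccccc12`: 100 nM; compound 3 `OCc1cn(Cc2ccc(Cl)cc2Cl)c2ccccc12`: 79 nM.

In a functional assay on NCI-H460 cells (Homo sapiens) for cytotoxicity, read by sulforhodamine B assay, with a stated time of 3 days (on this read-out higher numbers stand for weaker inhibition and lower numbers for stronger inhibition), compound 1 gives 40 nM, compound 2 gives 100 nM and compound 3 gives 79 nM. Compound 1 and compound 2 differ in more than one place, and the difference between the two cores is not broken down here. From compound 2 to compound 3 the change is chloro in place of hydrogen on an aromatic carbon, and it made a 1.3-fold lower number from compound 2 to compound 3 (0.10 log units; within the scatter). Compound 4 `OCc1cn(Cc2cccc(F)c2)c2ccc(Cl)cc12` is not yet measured; it arises from compound 1 by chloro in place of hydrogen on an aromatic carbon. This is the same kind of change, but the place differs: in compound 4 the chloro sits on a ring that is part of a fused system, meta and para to a fused ring, whereas in compound 3 it sits meta to a chloro group and para to a large group. Since the measured step from compound 2 to compound 3 stayed within the scatter, a similar small step is expected here, namely a 1.1-fold lower number from compound 1 to compound 4 (0.06 log units; within the scatter). Compound 4 is therefore estimated at 35 nM, between 15 nM and 90 nM.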

Compound 4, half-maximal inhibitory concentration: 70 nM
Compound 4: middle estimate off by 2.0-fold (0.30 log units), on the low side; low and high end bracket the measured number.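

In this assay, chloro in place of hydrogen on an aromatic carbon gave a 1.8-fold higher number from compound 1 to compound 4 (0.24 log units; within the scatter). Set beside the earlier step, the same change shows no difference between the two cores that can be told apart: the same change on two cores in this assay, a 1.3-fold lower number (0.10 log units; within the scatter) from compound 2 to compound 3 and a 1.8-fold higher number (0.24 log units; within the scatter) from compound 1 to compound 4, 2.2-fold (0.35 log units) apart, within the scatter of two such steps

This does not establish that the change is independent of the core: in compound 4 the chloro sits on a ring that is part of a fused system, and in compound 3 it does not, so core and place are not separated, and two steps make no rule for the series. The compounds shown leave open whether a group other than chloro, such as a methoxy group or an amine, on that same aromatic carbon would give a step beyond the scatter.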